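The source may report more compounds than this note shows. Statements on the series, on what has been measured and on what is new or still open speak of the compounds shown alone.

The measured compounds:
Compound 1 `C/C=C1/[C@H](O[C@@H]2O[C@H](CO)[C@@H](O)[C@H](O)[C@H]2O)OC=C(C(=O)OC)[C@H]1CC(=O)OC` gives > 15000 nM in a functional assay on SK-BR-3 cells (Homo sapiens) for antiproliferative activity, read by MTT assay, with a stated time of 72 h; on this read-out higher numbers stand for weaker inhibition and lower numbers for stronger inhibition; this is a limit of the assay.
Compound 2 `C=C(C)CCOC(=O)C[C@@H]1C(C(=O)OC)=CO[C@@H](O[C@@H]2O[C@H](COC(C)=O)[C@@H](OC(C)=O)[C@H](OC(C)=O)[C@H]2OC(C)=O)/C1=C/C` gives > 15000 nM in this assay; this too is a limit.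

Compound 1 therefore stands at the limit of > 15000 nM in this assay, at which 2 of the 2 values shown sit, and no number separates it from compound 2. The account now follows compound 1 to compound 3 `C/C=C1/[C@H](O[C@@H]2O[C@H](CO)[C@@H](O)[C@H](O)[C@H]2O)OC=C(C(=O)OC)[C@H]1CC(=O)OCc1ccc(OC)c(OC)c1`. The change is 3,4-dimethoxyphenyl in place of hydrogen on a saturated chain carbon bound to an oxygen next to a carbonyl group. For the measured compounds named here, no step between measured compounds is available, since both values shown are limits, so nothing in the data points to a direction for this change. Compound 3 is expected to remain near the limit in this assay, with a step from compound 1 that is expected not to exceed the usual scatter, namely a step that the limit leaves unreadable from compound 1 to compound 3. Compound 3 is estimated at 20000 nM, with a range from 5000 nM to 60000 nM, and it is expected that this assay may again report only a limit.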

Compound 3, half-maximal inhibitory concentration: > 15000 nM
Compound 3 gave a limit, no number (the forecaster's own chance of this, stated with the estimate: 70%); the middle value is on the limit's open side.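

For the compounds shown here, compound 3, like compound 1, sits at a limit and not at a number, so no step between compound 1 and compound 3 can be read: the limit of > 15000 nM in this assay, at which 3 of the 3 values shown sit. The compounds shown leave open whether the 3,4-dimethoxyphenyl change shifts activity at all in this assay, and which change, if any, would give a number there.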